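A few compounds are considered here, and "the series" means these few. Any claim that something is new, unique, unknown or untested is made for them only; others in the source may bear on it.

Compound 1 `CCC(=O)Nc1ccc(-c2nc3cc(C(F)(F)F)ccc3[nH]2)cc1` gives in an ADME assay on MDBK cells (Bos taurus) for cytotoxicity, read by MTT assay, with a stated time of 96 h (on this read-out lower numbers stand for higher toxicity in this test and higher numbers for lower toxicity in this test), a value of > 100000 nM, which is a limit of the assay and not a number.
Compound 2 `O=[N+]([O-])c1ccc(-c2nc3cc(C(F)(F)F)ccc3[nH]2)c([N+](=O)[O-])c1` gives in this assay 16000 nM.
Compound 3 `CCC(=O)Nc1ccc(-c2nc3ccccc3[nH]2)cc1` gives in this assay > 100000 nM, again a limit of the assay.

Going by the values given here, compound 2 thus carries the only number in the set; the other two values are limits. The difference between the core of compound 1 and the core of compound 2 is not broken down here. Compound 1 and compound 3 differ by hydrogen in place of trifluoromethyl on an aromatic carbon, and the step that the two limits leave unreadable from compound 1 to compound 3 cannot be read because of the limit of > 100000 nM in this assay, at which 2 of the 3 values shown sit. Compound 4 `O=[N+]([O-])c1ccc(-c2nc3ccccc3[nH]2)c([N+](=O)[O-])c1`, not yet measured, differs from compound 2 by hydrogen in place of trifluoromethyl on an aromatic carbon, the same change placed in the same way. Among the compounds with values here, since the only measured pair for this change gives no readable size, the expectation for compound 4 rests on compound 2 alone, whose value of 16000 nM serves as the anchor, with the step expected to stay within the usual scatter. In this assay the estimated value of compound 4 is 25000 nM, expected to lie between 8000 nM and 80000 nM, an expected step of a 1.6-fold higher number from compound 2 to compound 4 (0.19 log units; within the scatter).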

Compound 4, half-maximal cytotoxic concentration: 20000 nM
The estimate for compound 4 lay 1.3-fold (0.10 log units) above the measured number, within the range that was stated.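

In this assay the replacement of trifluoromethyl by hydrogen gives a 1.3-fold higher number from compound 2 to compound 4 (0.10 log units; within the scatter), so on this core the change does not move the number beyond the scatter. The same change on the core of compound 1, leading to compound 3, cannot be read, because both values there are limits of the assay and not numbers: the limit of > 100000 nM in this assay, at which 2 of the 4 values shown sit. The series thus holds a single readable measurement of this change, which shows how it behaves on one core but does not show that it would behave alike on the other, so nothing firm can be carried from one core to the other.

The compounds shown leave open how other groups at the same aromatic carbon, such as a nitrile, an amine or a carboxylic acid, would read in this assay. Also open, from the compounds shown here alone, is how a single nitro group or a longer chain on the amide would read on these cores.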